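The source may hold more compounds than are shown below. What is called first, only, known or untested is meant among the compounds shown, and "the series" means these compounds.

Measured in a functional assay on HaCaT cells (Homo sapiens) for inhibition, read by sulforhodamine B assay, with a stated time of 48 h; on this read-out lower numbers stand for stronger inhibition of growth and higher numbers for weaker inhibition of growth:

- Compound 1 `CC1(/C=C/c2ccccc2)C=CC(=O)O1`: 119000 nM
- Compound 2 `COc1ccc(/C=C/C2(C)C=CC(=O)O2)c(OC)c1`: 53600 nM
- Compound 3 `CC1(/C=C/c2ccccc2O)C=CC(=O)O1`: 57300 nM

In this assay, compound 3 lies within the scatter of compound 2 and clearly under compound 1. Compound 4 `COc1ccccc1/C=C/C1(C)C=CC(=O)O1` differs from compound 3 by methyl in place of hydrogen on an oxygen on an aromatic ring, hydroxy to methoxy. Among the measured compounds shown here, the one measured step bearing on this is a 2.1-fold lower number from compound 1 to compound 3 (0.32 log units; beyond the scatter), a modest one, where hydroxy took the place of hydrogen on an aromatic carbon. Compound 2, which also carries methoxy, gives 53600 nM, so a large loss seems unlikely. For the measured compounds named here, no measured step shows this exact change, so only a small shift towards a higher number is expected, within the scatter. The estimated change is a 1.2-fold higher number from compound 3 to compound 4 (0.09 log units; within the scatter). Compound 4 is expected at 70000 nM, within an estimated range of 35000 nM to 125000 nM.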

Compound 4, concentration for total growth inhibition: 30800 nM
Compound 4: the middle estimate sits 2.3-fold (0.36 log units) above what was measured, outside the stated range (below it).
By their numbers in this assay, from the lowest: compounds 4, 2 and 3 (each within the scatter of the next); then compound 1.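

In this assay, the free hydroxy on the aromatic ring is not needed to keep this level of growth inhibition: methyl in place of hydrogen on its oxygen stays within the scatter (a 1.9-fold lower number from compound 3 to compound 4 (0.27 log units; within the scatter)). The step that adds a single methoxy to the aromatic ring lies beyond the scatter (a 3.9-fold lower number from compound 1 to compound 4 (0.59 log units; beyond the scatter)), whereas hydrogen in place of the further methoxy of compound 2 does not (a 1.7-fold lower number from compound 2 to compound 4 (0.24 log units; within the scatter)). No measurement shown explains these steps. On these data alone, it remains open whether a longer ether such as ethoxy, or an amine, would hold up at this position.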